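Halogen Swap on the Indole Ring of a Diterpenoid Ester

The source may report more compounds than this note shows. Statements on the series, on what has been measured and on what is new or still open speak of the compounds shown alone.

Among the compounds with values here, compound 2 `COC(=O)[C@@]1(C)CCC=C2[C@@H]1CC[C@@H](C)[C@]2(C)Cc1c(C)[nH]c2c(Br)cccc12` stands at the higher end of the two numbers so far: in a functional assay on HBL-100 cells (Homo sapiens) for inhibition, read by sulforhodamine B assay, with a stated time of 48 h (a lower number here means a stronger inhibitor of growth, a higher number a weaker inhibitor of growth), compound 2 gives 27000 nM, while compound 1 `COC(=O)[C@@]1(C)CCC=C2[C@@H]1CC[C@@H](C)[C@]2(C)Cc1c(C)[nH]c2ccccc12` gives 14000 nM. Within the data shown here, the only measured step, a 1.9-fold higher number from compound 1 to compound 2 (0.29 log units; within the scatter), is bromo in place of hydrogen on an aromatic carbon and stays within the scatter. Compound 3 `COC(=O)[C@@]1(C)CCC=C2[C@@H]1CC[C@@H](C)[C@]2(C)Cc1c(C)[nH]c2c(Cl)cccc12` differs from compound 2 by chloro in place of bromo on an aromatic carbon. Among the measured compounds shown here, no measured pair exchanges one halogen for another, so the bromo-for-hydrogen step is the nearest guide; since that addition moved the number by only a 1.9-fold higher number from compound 1 to compound 2 (0.29 log units; within the scatter), a change from one halogen to a smaller one at the same carbon is expected to give a step of a 1.2-fold lower number from compound 2 to compound 3 (0.09 log units; within the scatter) in this assay, not beyond the scatter. Compound 3 is therefore estimated at 22000 nM, with a range from 9000 nM to 50000 nM.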

Compound 3, concentration for 50% growth inhibition: 22000 nM
Compound 3: the middle estimate sits on the measured number at the digits printed; low and high end bracket the measured number.
By their numbers in this assay, from the lowest: compounds 1, 3 and 2 (each within the scatter of the next).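

In this assay the exchange of one halogen for another at this aromatic carbon (a 1.2-fold lower number from compound 2 to compound 3 (0.09 log units; within the scatter)) stays within the scatter, so bromo and chloro cannot be told apart here. Chloro in place of hydrogen (a 1.6-fold higher number from compound 1 to compound 3 (0.20 log units; within the scatter)) also stays within the scatter, which means that a second halogen, like bromo before it, gives a number that cannot be separated from that of the unsubstituted compound 1. Nothing available offers an explanation for these small steps. On these data alone, whether fluoro, an amine or a carboxylic acid at this same carbon would give a step beyond the scatter remains open. So does the question of whether a carboxylic acid in place of the methyl ester on the shared core would move the number further than any change on the aromatic ring has so far.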